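Notes on compound 4 next to compound 2

The compounds below may be only part of what the source reports. "The series", "measured", "known", "first", "only" and "open" are said of these compounds alone.

Measured so far:
compound 1, `CCCCCCCCc1ccc(OCC(=O)Cn2nnc(SC)n2)cc1`, 31 nM
compound 2, `CCCCCCCCc1ccc(OCC(=O)Cn2nnc(-c3cccc(Cl)c3)n2)cc1`, 24 nM
compound 3, `CCCCCCCCc1ccc(OCC(=O)Cn2nnc(-c3ccncc3)n2)cc1`, 24 nM

All three numbers come from an assay on microsomes from brain for inhibition of Fatty-acid amide hydrolase 1 (Rattus norvegicus), read by fluorescence and HPLC, with a stated time of 60 min; on this read-out lower numbers stand for stronger inhibition and higher numbers for weaker inhibition. Compound 2 sits level with compound 3 at the digits printed, and compound 1 lies close to both: the step of a 1.3-fold lower number from compound 1 to compound 2 (0.11 log units; within the scatter) and the step of a 1.3-fold lower number from compound 1 to compound 3 (0.11 log units; within the scatter) are each within the scatter, as is the step of no change at the digits printed from compound 2 to compound 3 (within the scatter). On the numbers shown, nothing separates the three compounds beyond the scatter.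

Compound 4, `CCCCCCCCc1ccc(OCC(=O)Cn2nnc(-c3cccnc3)n2)cc1`, is not yet measured. It differs from compound 2 in one place: pyridin-3-yl in place of 3-chlorophenyl on an aromatic carbon.

Among the compounds with values here, the steps that bear on this change are the ones in which the methylsulfanyl group or the 3-chlorophenyl group was exchanged for another group on the same aromatic carbon. Each of them, a 1.3-fold lower number from compound 1 to compound 2 (0.11 log units; within the scatter), a 1.3-fold lower number from compound 1 to compound 3 (0.11 log units; within the scatter) and no change at the digits printed from compound 2 to compound 3 (within the scatter), stayed within the scatter. The exchange of 3-chlorophenyl for pyridin-4-yl in particular gave no change at the digits printed, and pyridin-3-yl is the same ring with the nitrogen in another position, so in this assay no step beyond the scatter is expected from compound 2 to compound 4. The step is estimated as a 1.0-fold higher number from compound 2 to compound 4 (0.02 log units; within the scatter). Compound 4 is expected to give about 25 nM, with a range from 12 nM to 50 nM.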

Compound 4, half-maximal inhibitory concentration: 23 nM
Compound 4: middle estimate off by 1.1-fold (0.04 log units), on the high side; the range from low to high includes it.
By their numbers in this assay, from the lowest: compounds 4, 2, 3 and 1 (each within the scatter of the next).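

In this assay, pyridin-3-yl in place of 3-chlorophenyl on this aromatic carbon gives a 1.0-fold lower number from compound 2 to compound 4 (0.02 log units; within the scatter); a carbon-only ring with a chlorine can thus give way to a ring with one hetero atom and one hydrogen-bond acceptor, here in a second pyridine isomer, without a step beyond the scatter. Within the data shown here, the exchange of pyridin-4-yl for pyridin-3-yl, which gives a 1.0-fold lower number from compound 3 to compound 4 (0.02 log units; within the scatter), is the first direct reading on the place of the ring nitrogen, and these two placements cannot be told apart in this assay. The step of a 1.3-fold lower number from compound 1 to compound 4 (0.13 log units; within the scatter) also stays within the scatter, so methylsulfanyl, 3-chlorophenyl, pyridin-4-yl and pyridin-3-yl on this carbon of the five-membered ring all read alike, with no exception among the four compounds.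

Nothing at hand explains why these groups read alike. Still open, on these data alone, is whether any group on this carbon moves the number beyond the scatter, for instance an amine, a carboxylic acid or a longer chain in place of the rings and the methylsulfanyl group.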